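A few compounds are considered here, and "the series" means these few. Any claim that something is new, unique, unknown or untested is made for them only; others in the source may bear on it.

Compounds measured so far in an assay on HepG2 cells for inhibition of 3-hydroxy-3-methylglutaryl-coenzyme A reductase (Homo sapiens); a lower number here means a stronger inhibitor, a higher number a weaker inhibitor:
- compound 1 `Cc1cc(-c2ccc(F)cc2)c(/C=C/[C@@H]2C[C@@H](O)CC(=O)O2)c(C(C)C)n1`: 50 nM
- compound 2 `CC(C)c1nc(C(C)(C)C)cc(-c2ccc(F)cc2)c1/C=C/[C@@H]1C[C@@H](O)CC(=O)O1`: 20 nM

Compound 2 stands at the lower of the two numbers in this assay, and its gap to compound 1 is beyond the scatter. For the measured compounds named here, the one measured step, a 2.5-fold lower number from compound 1 to compound 2 (0.40 log units; beyond the scatter), replaces a methyl with a tert-butyl on an aromatic carbon of the shared core and runs toward the lower number.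

Compound 3 `CC(C)c1nc(C2CCCCC2)cc(-c2ccc(F)cc2)c1/C=C/[C@@H]1C[C@@H](O)CC(=O)O1` is not yet measured. It differs from compound 2 by cyclohexyl in place of tert-butyl on an aromatic carbon. Going by the values given here, the only step that bears on it is the one from compound 1 to compound 2, which changed the group at the same place; that step was modest and in the lower direction. Nothing measured here shows what a further enlargement of the same group does, so the expectation rests on a single step and carries a wide range. Compound 3 is expected to land close to compound 2, with an estimated step of a 1.3-fold higher number from compound 2 to compound 3 (0.10 log units; within the scatter) in this assay, which is within the scatter. The estimate for compound 3 in this assay is 25 nM, with a range from 8 nM to 80 nM.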

Compound 3, half-maximal inhibitory concentration: 9.5 nM
Beside the measured number, compound 3's estimate is 2.6-fold (0.42 log units) above it, and the stated range covers the measured number.
By their numbers in this assay, from the lowest: compound 3; then compound 2; then compound 1.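

In this assay, cyclohexyl in place of tert-butyl on the aromatic carbon next to the ring nitrogen gives a 2.1-fold lower number from compound 2 to compound 3 (0.32 log units; beyond the scatter) and so extends the trend beyond tert-butyl, showing that this position also accepts a six-membered non-aromatic ring of carbon only. Cyclohexyl in place of methyl gives a 5.3-fold lower number from compound 1 to compound 3 (0.72 log units; beyond the scatter) in the same assay, which places compound 3 at the lowest number of the three and gives the order methyl, tert-butyl, cyclohexyl, with no compound against it. Nothing available explains why the number falls along this order.

The last change both adds carbons and introduces a ring, so these compounds cannot separate the contribution of group size from that of the ring itself, a question that cyclopentyl or a longer open chain such as n-hexyl would address. Also open, on these data alone, are whether the fall continues or reverses with cycloheptyl or phenyl at this carbon, and whether a ring carrying an amine or a hydroxyl group is accepted as well as the all-carbon cyclohexyl.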